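Chloro to Fluoro: What Compound 4 Might Show

This account rests on a few compounds, and the source may have more. Where it says the series, first, only, none or still open, it means among the compounds named here.

compound 1 `CC1(C)[C@H]2CC[C@]1(C)N(Cc1cn(-c3ccccc3O)nn1)C(=O)C2`: 230 nM
compound 2 `CC1(C)[C@H]2CC[C@]1(C)N(Cc1cn(-c3ccccc3C#N)nn1)C(=O)C2`: 100 nM
compound 3 `CC1(C)[C@H]2CC[C@]1(C)N(Cc1cn(-c3ccccc3Cl)nn1)C(=O)C2`: 70 nM

Of the compounds shown here, three sharing one core have been tested in a functional assay on A549 cells (Homo sapiens) for inhibition, read by MTT assay, with a stated time of 24 h; on this read-out higher numbers stand for weaker inhibition and lower numbers for stronger inhibition. Compound 3 gives the lowest of the three numbers, but its nearest neighbour is compound 2, and that gap, a 1.4-fold lower number from compound 2 to compound 3 (0.15 log units; within the scatter), is within the scatter, so the two cannot be ranked against each other. Only compound 1 stands clearly apart, with a 3.3-fold lower number from compound 1 to compound 3 (0.52 log units; beyond the scatter) and, toward compound 2, a 2.3-fold lower number from compound 1 to compound 2 (0.36 log units; beyond the scatter).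

Compound 4 `CC1(C)[C@H]2CC[C@]1(C)N(Cc1cn(-c3ccccc3F)nn1)C(=O)C2` is not yet measured. It differs from compound 3 by fluoro in place of chloro on an aromatic carbon. Among the measured compounds shown here, no measured step involves fluoro, so the closest guide is the exchange of one small group for another at this same carbon, the step from compound 2 to compound 3, which stayed within the scatter. The larger steps both start from hydroxy and do not bear directly on this change.

On that basis the estimated step is a 1.4-fold higher number from compound 3 to compound 4 (0.15 log units; within the scatter), most likely within or only slightly beyond the scatter. Compound 4 is therefore expected to give about 100 nM in this assay, with an estimated range from 50 nM to 250 nM.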

Compound 4, half-maximal inhibitory concentration: 240 nM
For compound 4 the middle estimate is 2.4-fold (0.38 log units) below the measured one; the range from low to high includes it.
By their numbers in this assay, from the lowest: compounds 3 and 2 (each within the scatter of the next); then compounds 1 and 4 (each within the scatter of the next).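

The exchange of chloro for fluoro at this aromatic carbon, with one heavy atom leaving and one entering and no hydrogen-bond donor or acceptor counted on either side, is not a neutral swap in this assay (it gives a 3.4-fold higher number from compound 3 to compound 4 (0.54 log units; beyond the scatter)), whereas the earlier exchange of cyano for chloro stayed within the scatter. The fluoro compound also separates from the nitrile (with a 2.4-fold higher number from compound 2 to compound 4 (0.38 log units; beyond the scatter)) but cannot be told apart from the hydroxy compound (with a 1.0-fold higher number from compound 1 to compound 4 (0.02 log units; within the scatter)), so the four substituents now fall into two groups at this carbon, chloro and cyano on the lower side and hydroxy and fluoro on the higher, and every step printed between the two groups lies beyond the scatter. Nothing available explains this grouping or why the two halogens part so clearly.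

On these data alone, whether bromo, methyl, methoxy or an amine on this same carbon would join the chloro and cyano pair or the hydroxy and fluoro pair remains open. Also open, as far as these compounds go, is whether the step from 2-chlorophenyl to 2-fluorophenyl would keep its size on any core other than the shared one.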